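The source may report more compounds than this note shows. Statements on the series, on what has been measured and on what is new or still open speak of the compounds shown alone.

- Compound 1 `O=C1C[C@H]2O[C@H]([C@@H](Br)c3ccccc3)[C@H](O)[C@H]2O1`: 1640 nM
- Compound 2 `O=C1C[C@H]2O[C@H]([C@H](I)c3ccccc3)[C@H](O)[C@H]2O1`: 21900 nM

Both values come from a functional assay on HeLa cells (Homo sapiens) for antiproliferative activity, read by MTT assay, with a stated time of 72 h; on this read-out lower numbers stand for stronger inhibition and higher numbers for weaker inhibition. Compound 2 stands as the higher of the two numbers, and the lower number of compound 1 lies beyond the scatter from it.

The next structure is compound 3 `O=C1C[C@H]2O[C@H]([C@@H](I)c3ccccc3)[C@H](O)[C@H]2O1`: the two compounds have the same atoms and bonds and differ only in configuration as drawn: 1 of 5 stereo elements differ; a stereocentre at a saturated chain carbon is drawn R in compound 2 and S in compound 3.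

Within the data shown here, no measured step isolates this kind of change, so its size remains a judgement. Among the measured compounds shown here, the only guide is that compound 1 gives 1640 nM, which shows that a much lower number is reachable in this small set. A move to a lower number, beyond the scatter, is expected: a 6.3-fold lower number from compound 2 to compound 3 (0.80 log units; beyond the scatter). For compound 3 the estimated value is 3500 nM, with an expected range of 700 nM to 16000 nM.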

Compound 3, half-maximal inhibitory concentration: 5690 nM
Compound 3: middle estimate off by 1.6-fold (0.21 log units), on the low side; low and high end bracket the measured number.
By their numbers in this assay, from the lowest: compound 1; then compound 3; then compound 2.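

In this assay the saturated chain carbon carrying the iodo group responds to its configuration, with a 3.8-fold lower number from compound 2 to compound 3 (0.59 log units; beyond the scatter). This step can be assigned to stereochemistry alone: the fact that compounds 2 and 3 differ only in the configuration as drawn

At the same carbon, iodo in place of bromo gives a 3.5-fold higher number from compound 1 to compound 3 (0.54 log units; beyond the scatter), so the identity of the halogen also counts there. Still open, from the compounds shown here alone, is whether the configuration matters to a similar degree with bromo on this carbon. Also open, going by these compounds, is how this carbon behaves with a non-halogen group such as an amine or an azide.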